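A few compounds are considered here, and "the series" means these few. Any claim that something is new, unique, unknown or untested is made for them only; others in the source may bear on it.

Measured so far in a functional assay on MKN-45 cells (Homo sapiens) for cytotoxicity, read by MTT assay, with a stated time of 72 h; on this read-out lower numbers stand for stronger inhibition and higher numbers for weaker inhibition:

compound 1 `CN(C)CCn1cnnc1-c1cc(Oc2ccc(NC(=O)N/N=C/c3ccc(Cl)cc3Cl)cc2F)ccn1`: 750 nM
compound 2 `CN(C)CCn1cnnc1-c1cc(Oc2ccc(NC(=O)N/N=C/c3ccc(O)c(Br)c3)cc2F)ccn1`: 1860 nM

Among the compounds with values here, compound 2 stands at the highest of the two numbers in this assay, with compound 1 the only neighbour, reached by a 2.5-fold higher number from compound 1 to compound 2 (0.39 log units; beyond the scatter). Within the data shown here, the one change behind that step was the swap of a 2,4-dichlorophenyl for a 3-bromo-4-hydroxyphenyl on a carbon with a double bond to nitrogen, and it moved the number beyond the usual scatter, though only modestly.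

Compound 3 `CN(C)CCn1cnnc1-c1cc(Oc2ccc(NC(=O)N/N=C/c3cccc(Cl)c3Cl)cc2F)ccn1` is not yet measured. It differs from compound 2 in one place: 2,3-dichlorophenyl in place of 3-bromo-4-hydroxyphenyl on a carbon with a double bond to nitrogen. Among the measured compounds shown here, this puts a dichlorophenyl back in place of the bromohydroxyphenyl, though with its chlorines arranged differently from those of compound 1, so the only step that bears on it is the one from compound 1 to compound 2, and it points the other way.

Compound 3 is therefore expected to give a number lower than compound 2, a step of about a 2.2-fold lower number from compound 2 to compound 3 (0.34 log units; beyond the scatter), roughly reversing what was seen before. The estimate for compound 3 in this assay is 850 nM, with a range from 350 nM to 2100 nM.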

Compound 3, half-maximal inhibitory concentration: 51 nM
Compound 3: the middle estimate sits 17-fold (1.22 log units) above what was measured; the whole stated range lies above it.
By their numbers in this assay, from the lowest: compound 3; then compound 1; then compound 2.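

In this assay, the change to 2,3-dichlorophenyl in place of 2,4-dichlorophenyl gives a 15-fold lower number from compound 1 to compound 3 (1.17 log units; beyond the scatter), so on this carbon the arrangement of the two chlorines matters, and not just the presence of a dichlorophenyl group. The change to 2,3-dichlorophenyl in place of 3-bromo-4-hydroxyphenyl gives a 36-fold lower number from compound 2 to compound 3 (1.56 log units; beyond the scatter), which shows that the read-out can shift far more at this one position than the earlier pair suggested, although compound 1, which also lacks the hydroxyl group, keeps a higher number than compound 3. Nothing available explains why these changes have such large effects.

The three compounds leave open whether both chlorines of the 2,3-dichlorophenyl group are needed, or whether a single chlorine would give a similar number. They also leave open how the read-out would respond if a methyl group, a methoxy group or an amine took the place of those chlorines, and whether the low number of compound 3 depends on chlorine itself.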